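Acyl thiourea benzimidazoles: a benzodioxin in place of phenyl

This account rests on a few compounds, and the source may have more. Where it says the series, first, only, none or still open, it means among the compounds named here.

Compound 1 `O=C(NC(=S)Nc1cccc(-c2nc3ccccc3[nH]2)c1)c1ccccc1` carries a benzoyl group on its thiourea and was tested in a functional assay on MDA-MB-231 cells (Homo sapiens) for cytotoxicity, read by WST assay, with a stated time of 48 h; on this read-out lower numbers stand for stronger inhibition and higher numbers for weaker inhibition. In this assay compound 1 reaches only the limit of the measurement, giving > 10000 nM, so no number is known for it. Two further members of the series were not examined: compound 2 `CCOc1ccc(C(=O)NC(=S)Nc2cccc(-c3nc4ccccc4[nH]3)c2)cc1OCC` is recorded as "not determined" (no result reported), and compound 3 `CCOc1ccc(C(=O)NC(=S)Nc2cc(-c3nc4ccccc4[nH]3)ccc2C)cc1OCC` as "not determined" (no result reported). The single limit of > 10000 nM in this assay, at which 1 of the 3 values shown sits, is therefore all that the measured side of the series offers.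

Compound 4 `O=C(NC(=S)Nc1cccc(-c2nc3ccccc3[nH]2)c1)c1ccc2c(c1)OCCO2` differs from compound 1 in one place (2,3-dihydro-1,4-benzodioxin-6-yl in place of phenyl on a carbonyl carbon), that is, 2,3-dihydro-1,4-benzodioxin-6-yl in place of phenyl on a carbonyl carbon. Among the compounds with values here, no pair of measured compounds shows what this kind of change does here, so the expected step from compound 1 to compound 4 is a step that the limit leaves unreadable from compound 1 to compound 4, which is a guess that it stays close to where compound 1 sits, most probably again at the limit. On that basis compound 4 is expected to give about 15000 nM, with a range from 3000 nM to 60000 nM.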

Compound 4, half-maximal inhibitory concentration: 400 nM
Compound 4: middle estimate off by 38-fold (1.57 log units), on the high side; the measured number lies below the stated range.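

In this assay, putting 2,3-dihydro-1,4-benzodioxin-6-yl in place of phenyl on a carbonyl carbon gives an at least 25-fold lower number from compound 1 to compound 4 (1.39 log units; beyond the scatter), so the group at this place can carry the series from the limit of the measurement to a real number. Before this result, the series offered no number to compare, only a limit: the limit of > 10000 nM in this assay, at which 1 of the 4 values shown sits.

The printed size of the step is a minimum and not an exact gap, and it comes from this one pair of compounds alone.

It remains open which part of the entering group matters, as the compounds shown include no methoxyphenyl group on the same carbonyl carbon to separate a single oxygen-bearing substituent from the closed ring. It is also unknown whether a simple amine or a carboxylic acid on the entering ring would keep a value near that of compound 4, 400 nM.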